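A few compounds are considered here, and "the series" means these few. Any claim that something is new, unique, unknown or untested is made for them only; others in the source may bear on it.

Series notes. Compound 1 `O=C(Nc1ccc(Sc2nc3ccccc3s2)c(Cl)c1)c1cc(Br)cc(Br)c1`, compound 2 `COc1ccccc1C(=O)Nc1ccc(Sc2nc3ccccc3s2)cc1` and compound 3 `COc1c(Br)cc(Br)cc1C(=O)Nc1ccc(Sc2nc3ccccc3s2)c(Cl)c1` have been run in an assay for inhibition of HSP60/HSP10 (Homo sapiens), with a stated time of 60 min; on this read-out lower numbers stand for stronger inhibition and higher numbers for weaker inhibition. In this assay compound 1 returns only a limit, > 100000 nM. In this assay compound 2 likewise returns a limit, > 100000 nM. In this assay compound 3 also returns a limit, > 100000 nM. All three readings sit at one point: the limit of > 100000 nM in this assay, at which 3 of the 3 values shown sit. The change hydrogen in place of methoxy on an aromatic carbon accordingly gives a step that the two limits leave unreadable from compound 3 to compound 1. How the cores of compound 2 and compound 3 differ is not broken down here. Going by the values given here, compound 4 `O=C(Nc1ccc(Sc2nc3ccccc3s2)cc1)c1ccccc1` is still to be measured; it differs from compound 2 by hydrogen in place of methoxy on an aromatic carbon, the same kind of change as the one from compound 3 to compound 1, where the place is additionally ortho to a bromo group and para to a bromo group. In this assay the step is expected to be a number no higher from compound 2 to compound 4 (the limit leaves the size open), resting on the unreadable step that the two limits leave unreadable from compound 3 to compound 1 and on the shared limit (the limit of > 100000 nM in this assay, at which 3 of the 3 values shown sit). Compound 4 is expected near 100000 nM, between 30000 nM and 300000 nM, most likely again only a limit.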

Compound 4, half-maximal inhibitory concentration: > 100000 nM
Compound 4 was reported as a limit; the forecaster's own chance of this, stated with the estimate: 85%; the middle value sits exactly at the limit.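

No step can be read from compound 2 to compound 4, as both readings are limits: the limit of > 100000 nM in this assay, at which 4 of the 4 values shown sit.
The compounds shown leave open how far any of these changes moves inhibition in this assay, as none of them gives a number.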